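A few compounds are considered here, and "the series" means these few. Any claim that something is new, unique, unknown or untested is made for them only; others in the source may bear on it.

Working notes on the series in an assay for inhibition of mitogen-activated protein kinase kinase kinase 14 (Homo sapiens), read by luminescence and ADP-Glo, with a stated time of 120 min, in the presence of a further agent that is not named here; on this read-out higher numbers stand for weaker inhibition and lower numbers for stronger inhibition. Compound 1 `CN(C)c1ccc(C#CC(C)(O)c2nccs2)cc1Nc1ncnc2[nH]ccc12` gives 22.5 nM. Compound 2 `CN(C)CCN(C)c1ccc(C#CC(C)(O)c2nccs2)cc1Nc1ncnc2[nH]ccc12` gives 484 nM. Compound 3 `CC(O)(C#Cc1ccc(N2CCCC2)c(Nc2ncnc3[nH]ccc23)c1)c1nccs1` gives 107 nM, which places it second highest of the three numbers: the step of a 4.8-fold higher number from compound 1 to compound 3 (0.68 log units; beyond the scatter) is beyond the scatter, as is the step of a 4.5-fold lower number from compound 2 to compound 3 (0.66 log units; beyond the scatter).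

The next compound is compound 4 `CC(O)(C#Cc1ccc(N2CCNCC2)c(Nc2ncnc3[nH]ccc23)c1)c1nccs1`, which is not yet measured in this assay. It differs from compound 3 in one place: piperazin-1-yl in place of pyrrolidin-1-yl on an aromatic carbon. The change keeps a saturated ring on the aromatic carbon but enlarges it and brings in a second nitrogen with a hydrogen-bond donor.

Going by the values given here, three measured steps bear on this position. The step of a 4.8-fold higher number from compound 1 to compound 3 (0.68 log units; beyond the scatter) is modest, the step of a 22-fold higher number from compound 1 to compound 2 (1.33 log units; beyond the scatter) is large, and the step of a 4.5-fold lower number from compound 2 to compound 3 (0.66 log units; beyond the scatter) is modest. Every change away from the dimethylamino group of compound 1 has raised the number, and the change that added a second nitrogen at this position, in compound 2, raised it most. A further modest rise in this assay is therefore expected for compound 4, with the step of a 2.3-fold higher number from compound 3 to compound 4 (0.37 log units; beyond the scatter) from compound 3 expected to stay well short of the step seen in compound 2. Compound 4 is expected to give about 250 nM, within a range of 80 nM to 800 nM.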

Compound 4, half-maximal inhibitory concentration: 47.9 nM
Compound 4: middle estimate off by 5.2-fold (0.72 log units), on the high side, outside the stated range (below it).
By their numbers in this assay, from the lowest: compound 1; then compound 4; then compound 3; then compound 2.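

In this assay, piperazin-1-yl on the aromatic carbon para to the 3-hydroxy-3-(1,3-thiazol-2-yl)but-1-yn-1-yl group gives a 2.2-fold lower number from compound 3 to compound 4 (0.35 log units; beyond the scatter) and thus shows that a second nitrogen at this position need not raise the number, as it did in compound 2. The step of a 10-fold lower number from compound 2 to compound 4 (1.00 log units; beyond the scatter) separates two groups that both carry a second nitrogen, so the nitrogen count alone does not set the number here, and the ring form of compound 4 stands well apart from the open chain of compound 2. Even so, a 2.1-fold higher number from compound 1 to compound 4 (0.33 log units; beyond the scatter) keeps dimethylamino at the lowest number of the four compounds, so no replacement shown has matched it. No measurement at hand accounts for these differences.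

Going by these compounds, it remains open whether the lower number of compound 4 goes with the ring nitrogen bearing its hydrogen or with the six-membered ring itself, a question that piperidin-1-yl, morpholin-4-yl or 4-methylpiperazin-1-yl on this carbon would address. Also open, on these data alone, is whether any group here can reach a number lower than that of compound 1, for instance a smaller amine such as methylamino.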